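A few compounds are considered here, and "the series" means these few. Any claim that something is new, unique, unknown or untested is made for them only; others in the source may bear on it.

Working notes on the series. Compound 1 `C#CCSc1nc(Nc2ccc(Cl)cc2)c2ccncc2n1` and compound 2 `C#CCSc1nc(Nc2ccc(Br)cc2)c2ccncc2n1` share one core and differ in a single group on the six-membered aromatic ring of carbon only. In a functional assay on MGC-803 cells (Homo sapiens) for inhibition, read by MTT assay, with a stated time of 72 h (on this read-out lower numbers stand for stronger inhibition and higher numbers for weaker inhibition), compound 1 gives 16400 nM. In this assay compound 2 gives 26000 nM. For the measured compounds named here, the single measured step, a 1.6-fold higher number from compound 1 to compound 2 (0.20 log units; within the scatter), keeps both numbers within the scatter of each other; on the numbers so far compound 2 stands at the highest of the two, a placing that the scatter does not separate from compound 1.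

Compound 3 `C#CCSc1nc(Nc2ccc([N+](=O)[O-])cc2)c2ccncc2n1` is not yet measured. It follows from compound 2 by nitro in place of bromo on an aromatic carbon. Going by the values given here, no measured step replaces a halogen with a nitro group. Among the compounds with values here, the only step available, a 1.6-fold higher number from compound 1 to compound 2 (0.20 log units; within the scatter), exchanges one halogen for another and stays within the scatter, so it offers no direction for the present change and bears on it only loosely. The expectation for this assay is thus no step beyond the scatter, with a wide range to cover the untested group. Compound 3 is expected to give about 25000 nM, between 7000 nM and 90000 nM. The expected step is a 1.0-fold lower number from compound 2 to compound 3 (0.02 log units; within the scatter), essentially flat.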

Compound 3, half-maximal inhibitory concentration: > 80000 nM
Compound 3 ended at the assay's limit; the forecaster's own chance of this, stated with the estimate: 12%; at least 3.2-fold (0.50 log units) between middle value and limit.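

In this assay compound 3 stands at a limit of the assay, which is a bound and not a number: the limit of > 80000 nM in this assay, at which 1 of the 3 values shown sits. The exchange of one halogen for another had shown no response beyond the scatter at this position, on the six-membered aromatic ring of carbon only and para to a large group, but the nitro group does give one, with an at least 3.0-fold higher number from compound 2 to compound 3 (0.48 log units; beyond the scatter) and with an at least 4.8-fold higher number from compound 1 to compound 3 (0.68 log units; beyond the scatter). Inhibition in these cells is therefore weaker with nitro than with either halogen, so the position is not indifferent to the group it carries, although the full size of the loss stays unknown and both steps give only its lower bound.

The three compounds do not separate the heavy atoms that nitro adds from its hydrogen-bond acceptors, so neither can be tied to the loss. On these data alone, it also remains open whether an amine or a methoxy group at the same place would stay with the halogens or fall with nitro, and whether any group here could give stronger inhibition than the chloro and bromo compounds.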